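This account rests on a few compounds, and the source may have more. Where it says the series, first, only, none or still open, it means among the compounds named here.

Measured compounds in an assay on cells for agonist activity at vitamin D3 receptor (Homo sapiens), with a stated time of 96 h; a lower number here means that less compound is needed, a higher number that more compound is needed for the effect:

Compound 1, `CCn1c(C(=O)NCC#N)ccc1C(CC)(CC)c1ccc(OCCC(O)(CC)CC)c(C)c1`: 1080 nM
Compound 2, `CCn1c(C(=O)Nc2ccc(OC(F)(F)F)cc2)ccc1C(CC)(CC)c1ccc(OCCC(O)(CC)CC)c(C)c1`: a limit of the assay, > 10000 nM
Compound 3, `CCOC(=O)C(CC(=O)OC)NC(=O)c1ccc(C(CC)(CC)c2ccc(OCCC(O)(CC)CC)c(C)c2)n1CC`: 21 nM

Compound 3 stands lowest of the two numbers given; its nearest neighbour is compound 1, which sits a 51-fold lower number from compound 1 to compound 3 (1.71 log units; beyond the scatter) away when read in the other direction. For compound 2 the assay reports only a limit, (the limit of > 10000 nM in this assay, at which 1 of the 3 values shown sits), so its step to compound 3 is read as an at least 470-fold lower number from compound 2 to compound 3 (2.67 log units; beyond the scatter) and its step from compound 1 as an at least 9.2-fold higher number from compound 1 to compound 2 (0.96 log units; beyond the scatter).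

Compound 4, `CCn1c(C(=O)NC(CC(=O)O)C(=O)OC)ccc1C(CC)(CC)c1ccc(OCCC(O)(CC)CC)c(C)c1`, is not yet measured. It differs from compound 3 in one place: a group of 9 heavy atoms (5 carbon, 4 oxygen; no ring) in place of a group of 11 heavy atoms (7 carbon, 4 oxygen; no ring), on an amide-type nitrogen. Both measured steps touch the same amide-type nitrogen and show that the substituent on it moves this assay strongly, with the step from compound 1 to compound 3 being large and that from compound 2 to compound 3 larger still. Neither step, however, exchanges one group of the present kind for a close relative of it, so the direction of the step to compound 4 is not fixed by what is shown.

Compound 4 is therefore expected to stay near compound 3, with a step of a 1.9-fold higher number from compound 3 to compound 4 (0.28 log units; within the scatter), and its estimated value in this assay is 40 nM, within a range from 12 nM to 150 nM.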

Compound 4, half-maximal effective concentration: 26 nM
Estimate against measurement, compound 4: 1.5-fold (0.19 log units) above; the measured number falls inside the stated range.
By their numbers in this assay, from the lowest: compounds 3 and 4 (each within the scatter of the next); then compound 1. At a limit, above all of these: compound 2.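

In this assay, a 1.2-fold higher number from compound 3 to compound 4 (0.09 log units; within the scatter), so exchanging the group of 11 heavy atoms for the group of 9 heavy atoms, which brings 1 hydrogen-bond donor where the leaving group has 0, leaves the number unchanged within the scatter on this amide-type nitrogen. For the compounds shown here, the earlier compounds showed only one group of this kind, whereas now two different groups without a ring both stand well apart from the cyanomethyl group, as a 42-fold lower number from compound 1 to compound 4 (1.62 log units; beyond the scatter) shows. Compound 2 has a limit of the assay rather than a number, so an at least 380-fold lower number from compound 2 to compound 4 (2.58 log units; beyond the scatter) gives only a bound: the limit of > 10000 nM in this assay, at which 1 of the 4 values shown sits.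

As far as these compounds go, with just these two groups of the kind in compounds 3 and 4, it stays open whether a single ester, an amine or a longer chain on an amide-type nitrogen would keep the number at this level. No property of any of these groups is measured here, so what sets the groups of compounds 3 and 4 apart from cyanomethyl and 4-(trifluoromethoxy)phenyl cannot be told.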